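Replacing fluoro with methoxy on the phenoxy ring of compound 3

The source may hold more compounds than are shown below. What is called first, only, known or untested is meant among the compounds shown, and "the series" means these compounds.

Of the compounds shown here, three with a shared core have so far been measured in an ADME assay for permeability, using PAMPA, with a stated time of 30 min, at pH 7.4; a higher number here means that the compound crosses the layer faster, a lower number that the compound crosses the layer more slowly. Compound 1 `COc1ccc(Oc2ccc3c(NCCCNCc4cc(F)ccc4OC)ccnc3c2)cc1` gives 317 10^-6 cm/s. Compound 2 `CC(C)Cc1ccc2c(NCCCNCc3ccco3)ccnc2c1` gives 23 10^-6 cm/s. Compound 3 `Fc1ccc(Oc2ccc3c(NCCCNCc4ccco4)ccnc3c2)cc1` gives 317 10^-6 cm/s, which is level with compound 1 at the digits shown and together with it the highest of the three numbers; the only change step recorded is a 14-fold higher number from compound 2 to compound 3 (1.14 log units; beyond the scatter), which puts compound 2 well apart from the other two.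

Compound 4 `COc1ccc(Oc2ccc3c(NCCCNCc4ccco4)ccnc3c2)cc1` is now to be measured in this assay. It differs from compound 3 in one place: methoxy in place of fluoro on an aromatic carbon. For the measured compounds named here, no recorded step concerns this exact exchange. Going by the values given here, the one step that exists, from compound 2 to compound 3, concerns a different position and a different pair of groups, so it does not bear directly on the change at hand. What can be said is that compound 1, which also carries the 4-methoxyphenoxy group, and compound 3, which carries 4-fluorophenoxy, show no difference at the digits shown. On that basis the step of a 1.1-fold lower number from compound 3 to compound 4 (0.02 log units; within the scatter) is expected to stay within the scatter, with no direction favoured. Compound 4 is therefore estimated at 300 10^-6 cm/s, in a range from 150 10^-6 cm/s to 600 10^-6 cm/s.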

Compound 4, apparent permeability: 317 10^-6 cm/s
The estimate for compound 4 lay 1.1-fold (0.02 log units) below the measured number; measured number inside the range.
By their numbers in this assay, from the lowest: compound 2; then compounds 1, 3 and 4 (each within the scatter of the next).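

In this assay, for the compounds shown here, methoxy in place of fluoro on an aromatic carbon, para to a large group, gives no change at the digits printed from compound 3 to compound 4 (within the scatter), so this is the first direct reading of this exchange, and at this place it leaves the number where it was. The larger 4-methoxyphenoxy group in place of isobutyl gives a 14-fold higher number from compound 2 to compound 4 (1.14 log units; beyond the scatter), a step that matches a 14-fold higher number from compound 2 to compound 3 (1.14 log units; beyond the scatter), while furan-2-yl in place of 5-fluoro-2-methoxyphenyl on the saturated chain carbon gives no change at the digits printed from compound 1 to compound 4 (within the scatter), so with 4-methoxyphenoxy held in place that exchange also leaves the number unchanged. Nothing in the information available accounts for either the unchanged numbers or the large steps from compound 2.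

The compounds shown leave open whether this place tolerates any group, since fluoro and methoxy are the only two seen on the phenoxy ring, and a carboxylic acid or a dimethylamino group there might not give the same result. They also leave open whether the phenoxy ring itself matters or whether a plain hydrogen in place of fluoro or methoxy would keep the number at this level.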